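Sirtuin-6 series: carboxy entering at the amide-side chain carbon

A few compounds are considered here, and "the series" means these few. Any claim that something is new, unique, unknown or untested is made for them only; others in the source may bear on it.

Measured in an assay for inhibition of NAD-dependent protein deacylase sirtuin-6 (Homo sapiens), read by HPLC, with stated times of 15 min and 1 h, tested at 333 uM; a higher number here means more inhibition at the concentration tested (going by the name of the read-out), a lower number less inhibition:
Compound 1 `O=C(CCCSC[C@H](NC(=O)OCc1ccccc1)C(=O)Nc1ccccc1)NCc1ccccc1`: 30%
Compound 2 `CCCCCCCCCCNC(=O)CCCSC[C@H](NC(=O)OCc1ccccc1)C(=O)Nc1ccccc1`: 28%
Compound 3 `CNC(=O)CCCSC[C@H](NC(=O)OCc1ccccc1)C(=O)Nc1ccccc1`: "not active" (no number reported)

Compound 3 stands without a number in this assay ; it is recorded only as "not active" (no number reported). Compound 4 `O=C(O)CNC(=O)CCCSC[C@H](NC(=O)OCc1ccccc1)C(=O)Nc1ccccc1` differs from compound 3 by carboxy in place of hydrogen on a saturated chain carbon bound to an amide-type nitrogen. Within the data shown here, the one measured step at this place, a number 2 percentage points lower from compound 1 to compound 2 (within the scatter), exchanges one group for another and lies within the scatter; it does not cover the entry of a carboxy group, so no step size can be carried over. Compounds 1 and 2, with larger groups here, give numbers; compound 3, with methyl, gives none. Compound 4 is expected to stay low, estimated at 10% with a range of 0% to 28%, and it may well be reported only as not active.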

Compound 4, a percentage reported as inhibition, at one concentration (the size of the read-out at that concentration, not a potency): 53%
Estimate against measurement, compound 4: 43 percentage points below; the whole stated range lies below it.
By their numbers in this assay, from the lowest: compounds 2 and 1 (each within the scatter of the next); then compound 4.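

Here a number 25 percentage points higher from compound 2 to compound 4 (beyond the scatter) and a number 23 percentage points higher from compound 1 to compound 4 (beyond the scatter) give the first separation at this place in this assay, since the exchange of nonyl for phenyl stayed within the scatter. The carboxy group on the saturated chain carbon bound to an amide-type nitrogen thus gives a higher number than the two larger groups, and compound 4 has a number where compound 3, with methyl, has none. Nothing available explains this gain.

Open, from the compounds shown here alone, is whether the carboxylic acid itself is needed, which its methyl ester or primary amide would test. A longer chain carrying the carboxylic acid, or a tetrazole in its place, also remains to be read at this position.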